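This account rests on a few compounds, and the source may have more. Where it says the series, first, only, none or still open, it means among the compounds named here.

Working notes on an in vivo ADME assay on the whole organism (plasma) for pharmacokinetics, with Rattus norvegicus as the target, at a dose of 5 mg/kg by the intravenous route; a higher number here means faster removal of the compound, a lower number slower removal. Of the compounds shown here, two have measured numbers so far. Compound 1 (`CCNC(=O)c1ccccc1CCC(SCC(CC)C(=O)O)c1cccc(OCc2ccc3ccc(Cl)cc3n2)c1`) gives 106 mL/min/kg, and compound 2 (`O=C(O)CCSC(CCc1ccccc1-c1nc[nH]n1)c1cccc(OCc2ccc3ccc(Cl)cc3n2)c1`) gives 64 mL/min/kg. These two values lie within the usual scatter of each other, so compound 2 does not stand apart from compound 1. Compound 3 (`CS(=O)(=O)Nc1ccccc1CCC(SCCC(=O)O)c1cccc(OCc2ccc3ccc(Cl)cc3n2)c1`) is still unmeasured. It carries methanesulfonamido in place of 1H-1,2,4-triazol-3-yl, on an aromatic carbon of a six-membered aromatic ring of carbon only, ortho to a large group (methanesulfonamido in place of 1H-1,2,4-triazol-3-yl on an aromatic carbon). Within the data shown here, no measured pair shows a change at this place, so the data give no size or direction for this step. The expectation therefore stays close to compound 2 at 64 mL/min/kg, with no change beyond the scatter. The expected step is a 1.1-fold lower number from compound 2 to compound 3 (0.03 log units; within the scatter). The estimate for compound 3 is 60 mL/min/kg, with an expected range of 30 mL/min/kg to 110 mL/min/kg.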

Compound 3, clearance: 131 mL/min/kg
Beside the measured number, compound 3's estimate is 2.2-fold (0.34 log units) below it, outside the stated range (above it).
By their numbers in this assay, from the lowest: compounds 2, 1 and 3 (each within the scatter of the next, the first and the last beyond it).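

In this assay, among these compounds, the aromatic carbon ortho to a large group responds to substitution: methanesulfonamido in place of 1H-1,2,4-triazol-3-yl gives a 2.0-fold higher number from compound 2 to compound 3 (0.31 log units; beyond the scatter) and is the only step that can be read at this place. The leaving and entering groups have the same counts of heavy atoms, hydrogen-bond donors and acceptors, and neither carries a net charge, so these counts do not separate compound 2 from compound 3; the five-membered aromatic ring occurs only in the group that leaves, the sulfur and oxygen atoms only in the group that enters. Nothing measured here accounts for the step.

The compounds shown leave open whether the step follows from the arrival of methanesulfonamido or the departure of the ring. Acetamido or 1H-tetrazol-5-yl on the same carbon would bear on that question.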